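The source may report more compounds than this note shows. Statements on the series, on what has been measured and on what is new or still open speak of the compounds shown alone.

Working notes on a three-compound set of pyrazole-bearing analogues run in a functional assay on BT-549 cells (Homo sapiens) for cytotoxicity, read by sulforhodamine B assay, with a stated time of 48 h, tested at 1 uM (on this read-out higher numbers stand for a weaker effect at the one concentration tested and lower numbers for a stronger effect), with a fourth analogue awaiting a number.

Compound 1 `COc1cc(C)cc(-c2c(-c3ccnc(-c4ccc(N(C)C)cc4)c3)cnn2CC#N)c1` gives -29%. Compound 2 `COc1cc(C)cc(-c2nn(CC#N)cc2-c2ccnc(-c3ccc(N(C)C)cc3)c2)c1` gives -10%, the second highest of the three numbers; it sits nearest to compound 3 `COc1cc(C)cc(-c2nn(CC#N)cc2-c2ccc(-c3cccc(C(C)=O)c3)nc2)c1`, which gives 5%, a value higher than that of compound 2 by more than the usual scatter, and furthest from compound 1, whose value lies below that of compound 2 by more than the scatter.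

The next analogue is compound 4 `Cc1cc(O)cc(-c2nn(CC#N)cc2-c2ccnc(-c3ccc(N(C)C)cc3)c2)c1`. Its difference from compound 2 is hydrogen in place of methyl on an oxygen on an aromatic ring, so the change is methoxy to hydroxy on the 3-methoxy-5-methylphenyl group, which becomes 3-hydroxy-5-methylphenyl. For the measured compounds named here, no measured pair in this set shows such a change, so there is nothing to anchor the direction. The step from compound 2 to compound 4 is therefore expected to be small, a number 2 percentage points higher from compound 2 to compound 4 (within the scatter), and not beyond the scatter in either direction. On that basis compound 4 is estimated at -8%, with a range from -30% to 14%.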

Compound 4, a percentage reported as activity, at one concentration (the size of the read-out at that concentration, not a potency): 4%
Compound 4: middle estimate off by 12 percentage points, on the low side; the measured number falls inside the stated range.
By their numbers in this assay, from the lowest: compound 1; then compound 2; then compounds 4 and 3 (each within the scatter of the next).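

In this assay, the change from 3-methoxy-5-methylphenyl to 3-hydroxy-5-methylphenyl gives a number 14 percentage points higher from compound 2 to compound 4 (beyond the scatter), which reads as a weaker effect at the one concentration tested. For the compounds shown here, this is the first comparison between compounds that differ in one place, and it shows that the methyl on this oxygen cannot be exchanged for hydrogen without a shift in the read-out. No supporting data on hand bear on the reason for this shift.

The compounds shown leave open whether a longer chain on the same oxygen, such as ethyl, would move the read-out in the opposite direction or leave it unchanged. They also leave open how an amine in place of the hydroxy group would read, and whether the same methoxy-to-hydroxy step would hold on the cores of compound 1 and compound 3.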